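Moving the methoxy group on the aryl ring: working notes

The source may hold more compounds than are shown below. What is called first, only, known or untested is meant among the compounds shown, and "the series" means these compounds.

compound 1 `COC(=O)C1=C(C)N=C(C)/C(=C(\O)OC)C1c1cccc(OC)c1`: 191 nM
compound 2 `COC(=O)C1=C(C)N=C(C)/C(=C(\O)OC)C1c1ccc(Cl)cc1`: 8130 nM
compound 3 `COC(=O)C1=C(C)NC(C)=C(C(=O)OC)C1c1ccccc1`: 28.2 nM

All three values come from a functional assay (muscle tissue) with Cavia porcellus as the target; a lower number here means that less compound is needed, a higher number that more compound is needed for the effect. Compound 1 holds the middle place of the three numbers, with compound 3 at 28.2 nM lower and compound 2 at 8130 nM higher.

The next compound to test is compound 4 `COC(=O)C1=C(C)N=C(C)/C(=C(\O)OC)C1c1ccccc1OC`. It carries 2-methoxyphenyl in place of 3-methoxyphenyl on a saturated ring carbon.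

Among the measured compounds shown here, only one measured step bears on this change, and it acts at the same ring carbon: a 43-fold higher number from compound 1 to compound 2 (1.63 log units; beyond the scatter). That step is large, so this place in the series can respond strongly. However, it exchanges the substituent as well as its position, so it gives no direction for a methoxy group that merely moves. For the measured compounds named here, with no measured pair isolating position alone, a shift beyond the scatter in this assay is not expected, though the uncertainty is wide.

The expected outcome is a 1.6-fold lower number from compound 1 to compound 4 (0.20 log units; within the scatter). For compound 4 the estimated value is 120 nM, with an expected range of 25 nM to 600 nM.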

Compound 4, half-maximal effective concentration: 57.5 nM
For compound 4 the middle estimate is 2.1-fold (0.32 log units) above the measured one, and the stated range covers the measured number.
By their numbers in this assay, from the lowest: compound 3; then compound 4; then compound 1; then compound 2.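

In this assay the two compounds hold the same atoms joined differently, so a 3.3-fold lower number from compound 1 to compound 4 (0.52 log units; beyond the scatter) isolates position: moving the methoxy group alone gives a modest change at this ring carbon. The earlier step could not separate substituent from position, and a 140-fold lower number from compound 2 to compound 4 (2.15 log units; beyond the scatter) does not separate them either, since both differ in this pair. No evidence on the cause of the positional change is available.

Open, as far as these compounds go, is how much of the large step from the 4-chlorophenyl compound belongs to the chlorine and how much to its position, which 4-methoxyphenyl or 2-chlorophenyl on the same carbon would address. Also open, from the compounds shown here alone, is whether the preference for 2-methoxyphenyl over 3-methoxyphenyl holds for a longer chain such as ethoxy, or for an amine on the aryl ring.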